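This account rests on a few compounds, and the source may have more. Where it says the series, first, only, none or still open, it means among the compounds named here.

Values in a functional assay on ECa-109 cells (Homo sapiens) for cytotoxicity, read by MTT assay, with a stated time of 72 h; a higher number here means a weaker inhibitor, a lower number a stronger inhibitor:
- compound 1 `CN(C)c1ccc(C=C2C(=O)N(c3ccc(Cl)cc3)N(c3ccc(Cl)cc3)C2=O)cc1`: > 128000 nM (a limit)
- compound 2 `COc1cccc(C=C2C(=O)N(c3ccc(Cl)cc3)N(c3ccc(Cl)cc3)C2=O)c1OC`: 6800 nM

Within the data shown here, compound 2 carries the only true number so far. Compound 1 gives no number, only a limit: the limit of > 128000 nM in this assay, at which 1 of the 2 values shown sits.

The next compound to be tested is compound 3 `O=C1C(=Cc2c[nH]c3ccccc23)C(=O)N(c2ccc(Cl)cc2)N1c1ccc(Cl)cc1`. Its difference from compound 2 is 1H-indol-3-yl in place of 2,3-dimethoxyphenyl on a double-bonded chain carbon bound to a double-bonded ring carbon.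

Among the measured compounds shown here, one measured step bears on this change, since it alters the group at the same place: an at least 18-fold lower number from compound 1 to compound 2 (1.27 log units; beyond the scatter). That step is large and beyond the scatter, so the read-out in this assay can clearly respond to the group carried here. For the measured compounds named here, it is only a single step, however, and one end of it is a limit. It involves neither the entering group nor any other two-ring group. Going by the values given here, with compound 2 at 6800 nM as the only measured number, the better of just two results, a modest drift towards a weaker inhibitor seems more likely than a gain. The expected change is a 2.1-fold higher number from compound 2 to compound 3 (0.31 log units; beyond the scatter), with wide uncertainty. For compound 3 the estimated value is 14000 nM, with an expected range from 3000 nM to 70000 nM.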

Compound 3, half-maximal inhibitory concentration: 23400 nM
The estimate for compound 3 lay 1.7-fold (0.22 log units) below the measured number; low and high end bracket the measured number.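

In this assay the exchange of 2,3-dimethoxyphenyl for 1H-indol-3-yl gives a 3.4-fold higher number from compound 2 to compound 3 (0.54 log units; beyond the scatter), which shows that a group with a five-membered aromatic ring and a hydrogen-bond donor can stand on this double-bonded chain carbon and still give a measured number, though a weaker one. Against 4-(dimethylamino)phenyl the same entering group gives an at least 5.4-fold lower number from compound 1 to compound 3 (0.73 log units; beyond the scatter), which places 2,3-dimethoxyphenyl first, 1H-indol-3-yl in the middle and 4-(dimethylamino)phenyl last among the three groups at this place. The end of that step at compound 1 is a limit and not a number: the limit of > 128000 nM in this assay, at which 1 of the 3 values shown sits.

The compounds shown leave open which of the counted differences between the leaving and the entering group matters for this read-out: the hydrogen-bond donor, the second ring or the loss of the two oxygens. As far as these compounds go, a plain phenyl ring, a pyridine ring or a methylated indole at this place would help separate these, and the two 4-chlorophenyl groups of the shared core stay the same throughout, so their part in the result remains unknown.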